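This account rests on a few compounds, and the source may have more. Where it says the series, first, only, none or still open, it means among the compounds named here.

Measured compounds:
compound 1 `COc1cc2c(Oc3ccc(NC(=O)c4cc(-c5ccccc5)nc5ccc(F)cc45)cc3F)ccnc2cc1OCCCN1CCCCC1`: 30 nM
compound 2 `COc1cccc(-c2cc(C(=O)Nc3ccc(Oc4ccnc5cc(OCCCN6CCCCC6)c(OC)cc45)c(F)c3)c3cc(F)ccc3n2)c1`: 690 nM
compound 3 `COc1ccc(-c2cc(C(=O)Nc3ccc(Oc4ccnc5cc(OCCCN6CCCCC6)c(OC)cc45)c(F)c3)c3cc(F)ccc3n2)cc1`: 260 nM

These three share one core and differ only in the aryl group attached next to the ring nitrogen. In a functional assay on MKN-45 cells (Homo sapiens) for cytotoxicity, read by MTT assay, with a stated time of 72 h (a lower number here means a stronger inhibitor, a higher number a weaker inhibitor), compound 3 stands second highest of the three numbers; its nearest neighbour is compound 2, at a 2.7-fold lower number from compound 2 to compound 3 (0.42 log units; beyond the scatter), while compound 1 lies furthest away, at an 8.7-fold higher number from compound 1 to compound 3 (0.94 log units; beyond the scatter). Compound 4 `COc1cc2c(Oc3ccc(NC(=O)c4cc(-c5ccc(Cl)cc5Cl)nc5ccc(F)cc45)cc3F)ccnc2cc1OCCCN1CCCCC1` carries the change (2,4-dichlorophenyl in place of 4-methoxyphenyl on an aromatic carbon). For the measured compounds named here, the steps that bear on this are a 23-fold higher number from compound 1 to compound 2 (1.36 log units; beyond the scatter), an 8.7-fold higher number from compound 1 to compound 3 (0.94 log units; beyond the scatter) and a 2.7-fold lower number from compound 2 to compound 3 (0.42 log units; beyond the scatter): each added methoxy group raised the number, and the position of that group mattered by a modest amount. Going by the values given here, no measured step involves a chlorine, and no compound carries two substituents on this ring, so the data give no direct guide. Substituted aryl groups have so far given higher numbers than the unsubstituted one in compound 1, so compound 4 is expected to stay in the range of compounds 2 and 3 rather than return to compound 1. The step from compound 3 is therefore estimated as small, a 1.2-fold lower number from compound 3 to compound 4 (0.07 log units; within the scatter), with a wide band of doubt. Compound 4 is expected at 220 nM, between 40 nM and 1200 nM.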

Compound 4, half-maximal inhibitory concentration: 250 nM
The estimate for compound 4 lay 1.1-fold (0.06 log units) below the measured number; low and high end bracket the measured number.
By their numbers in this assay, from the lowest: compound 1; then compounds 4 and 3 (each within the scatter of the next); then compound 2.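

In this assay, 2,4-dichlorophenyl in place of 4-methoxyphenyl at this position next to the ring nitrogen gives a 1.0-fold lower number from compound 3 to compound 4 (0.02 log units; within the scatter), so a ring with two chlorines and no oxygen reads the same as the ring with one methoxy group. Compared with the other two compounds, there is a 2.8-fold lower number from compound 2 to compound 4 (0.44 log units; beyond the scatter) and an 8.3-fold higher number from compound 1 to compound 4 (0.92 log units; beyond the scatter); all three substituted phenyl groups shown thus give higher numbers than the plain phenyl, and this gap to compound 1 is not confined to methoxy groups. Nothing measured on these compounds bears on the cause of these steps.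

Going by these compounds, with both chlorines changed together, the part played by each remains open. On these data alone, it is also open whether a single fluorine, an amino group on the phenyl or a pyridine ring in its place would come closer to compound 1.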